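Swapping a nitro for a methoxy on the benzyl ring

The source may hold more compounds than are shown below. What is called first, only, known or untested is meant among the compounds shown, and "the series" means these compounds.

Measured compounds:
compound 1 `COc1cccc(OC)c1OCCNCCOc1ccccc1OCc1cccc(Cl)c1` 5900 nM
compound 2 `COc1cccc(OC)c1OCCNCCOc1ccccc1OCc1ccccc1[N+](=O)[O-]` 13200 nM
compound 3 `COc1cccc(OC)c1OCCNCCOc1ccccc1OCc1ccc([N+](=O)[O-])cc1` 12000 nM

In a functional assay on PC-3 cells (Homo sapiens) for cytotoxicity, read by sulforhodamine B assay (on this read-out lower numbers stand for stronger inhibition of growth and higher numbers for weaker inhibition of growth), compound 3 stands second highest of the three numbers; its values and those of compound 2 lie within the scatter of each other, while a 2.0-fold higher number from compound 1 to compound 3 (0.31 log units; beyond the scatter). Compound 4 `COc1ccc(COc2ccccc2OCCNCCOc2c(OC)cccc2OC)cc1` carries methoxy in place of nitro on an aromatic carbon. For the measured compounds named here, no measured step exchanges a nitro for a methoxy. Going by the values given here, the steps that bear on the benzyl ring are a 2.2-fold higher number from compound 1 to compound 2 (0.35 log units; beyond the scatter) and a 2.0-fold higher number from compound 1 to compound 3 (0.31 log units; beyond the scatter); they show that a change of this substituent can shift this assay modestly, and a 1.1-fold lower number from compound 2 to compound 3 (0.04 log units; within the scatter) shows that moving the nitro barely matters. The step from compound 3 to compound 4 is therefore expected to be small, a 1.3-fold lower number from compound 3 to compound 4 (0.12 log units; within the scatter), with compound 4 estimated at 9000 nM (range 4000 nM to 25000 nM).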

Compound 4, concentration for 50% growth inhibition: 8500 nM
Beside the measured number, compound 4's estimate is 1.1-fold (0.02 log units) above it; measured number inside the range.
By their numbers in this assay, from the lowest: compounds 1, 4, 3 and 2 (each within the scatter of the next, the first and the last beyond it).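

In this assay, for the compounds shown here, the first exchange of a nitro for a methoxy at this position, para to a large group, gives a 1.4-fold lower number from compound 3 to compound 4 (0.15 log units; within the scatter) and so leaves the number unresolved from that of the nitro compound. With a 1.6-fold lower number from compound 2 to compound 4 (0.19 log units; within the scatter) and a 1.4-fold higher number from compound 1 to compound 4 (0.16 log units; within the scatter) as its other steps, compound 4 also cannot be separated from compound 2 or compound 1, although those two differ beyond the scatter. No measurement here offers an explanation for these small steps. As far as these compounds go, whether an amine or a carboxylic acid at this position would shift the number more clearly remains open, as does the effect of a longer chain in place of the methoxy.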